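Replacing 4-chlorophenyl with 2,6-difluorophenyl: an expected step

A few compounds are considered here, and "the series" means these few. Any claim that something is new, unique, unknown or untested is made for them only; others in the source may bear on it.

Measured so far in a functional assay on HepG2 cells (Homo sapiens) for inhibition, read by MTT assay; a lower number here means a stronger inhibitor, a higher number a weaker inhibitor
compound 1 `COc1cc2ncnc(Nc3ccc(NC(=O)c4cccc(C)c4)cc3)c2cc1OC` gives 7500 nM
compound 2 `CCc1ccc(C(=O)Nc2ccc(Nc3ncnc4cc(OC)c(OC)cc34)cc2)cc1` gives 72000 nM
compound 3 `COc1cc2ncnc(Nc3ccc(NC(=O)c4ccc(Cl)cc4)cc3)c2cc1OC` gives 28000 nM

Compound 3 takes the middle place among these numbers, with a 3.7-fold higher number from compound 1 to compound 3 (0.57 log units; beyond the scatter) on one side and a 2.6-fold lower number from compound 2 to compound 3 (0.41 log units; beyond the scatter) on the other. Compound 4 `COc1cc2ncnc(Nc3ccc(NC(=O)c4c(F)cccc4F)cc3)c2cc1OC` has not yet been measured. It differs from compound 3 by a single change, 2,6-difluorophenyl in place of 4-chlorophenyl on a carbonyl carbon in short, 2,6-difluorophenyl in place of 4-chlorophenyl on a carbonyl carbon.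

All three measured steps concern this same place. The largest is a 9.6-fold higher number from compound 1 to compound 2 (0.98 log units; beyond the scatter) and it shows that swaps here can move the number beyond the scatter. None of the three involves 2,6-difluorophenyl, so they suggest a likely size but no direction. The best single guess therefore stays close to compound 3, with a modest step either way remaining possible.

The expected outcome is a 1.4-fold lower number from compound 3 to compound 4 (0.15 log units; within the scatter) with no shift beyond the scatter foreseen. Compound 4 is estimated at 20000 nM in this assay with 7000 nM to 70000 nM as its expected range.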

Compound 4, half-maximal inhibitory concentration: 17000 nM
Estimate against measurement, compound 4: 1.2-fold (0.07 log units) above, and the stated range covers the measured number.
By their numbers in this assay, from the lowest: compound 1; then compounds 4 and 3 (each within the scatter of the next); then compound 2.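

In this assay, the swap to 2,6-difluorophenyl gives a 1.6-fold lower number from compound 3 to compound 4 (0.22 log units; within the scatter), so exchanging this group for 4-chlorophenyl on the carbonyl carbon produces no readable change. The new group is, however, clearly separated from the two other groups tested here, with a 4.2-fold lower number from compound 2 to compound 4 (0.63 log units; beyond the scatter) and a 2.3-fold higher number from compound 1 to compound 4 (0.36 log units; beyond the scatter), which places it inside the span already set by 3-methylphenyl and 4-ethylphenyl rather than outside it. Nothing available explains why these numbers differ.

As far as these compounds go, whether an amine or a carboxylic acid on this ring would bring the number lower than that of compound 1 stays open. So does whether the lower number of compound 1 belongs to the methyl group itself or to where it sits on the ring, which these compounds cannot separate.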